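The source may hold more compounds than are shown below. What is called first, only, known or untested is meant among the compounds shown, and "the series" means these compounds.

Of the compounds shown here, three that share one core have been tested in a functional assay on 786-0 cells (Homo sapiens) for inhibition, read by sulforhodamine B assay, with a stated time of 48 h; a higher number here means a weaker inhibitor of growth, a lower number a stronger inhibitor of growth. Compound 2, `COc1ccc(CNc2nc3cc(N)cc(N)c3nc2-c2ccccc2)cc1OC`, is the only one that returns a plain number: in this assay compound 2 gives 34700 nM. Compound 1, `CCOC(=O)[C@H](CCC(=O)O)NC(=O)c1ccc(CNc2nc3cc(N)cc(N)c3nc2-c2ccccc2)cc1`, carries a different group on the same core; for compound 1 the value < 100000 nM is a limit of the assay, not a number. Compound 3, `COc1cc(CNc2nc3cc(N)cc(N)c3nc2-c2ccccc2)cc(OC)c1OC`, carries an additional methoxy group; for compound 3 the value < 50200 nM is likewise a limit. From the compounds shown here alone, the step from compound 2 to compound 3 is therefore a step that the limit leaves unreadable from compound 2 to compound 3, since the limit of < 50200 nM in this assay, at which 1 of the 3 values shown sits, hides its size, and the limit of < 100000 nM in this assay, at which 1 of the 3 values shown sits, leaves the position of compound 1 equally open.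

Compound 4, `COc1ccc(CNc2nc3cc(N)cc(N)c3nc2-c2ccccc2)cc1`, differs from compound 2 by hydrogen in place of methoxy on an aromatic carbon. Neither of the measured steps can be read, so none of them points to a direction for this change. With nothing to argue for a shift, the expectation is that compound 4 stays near compound 2, with no step beyond the usual scatter. The step from compound 2 to compound 4 is expected to be a 1.0-fold higher number from compound 2 to compound 4 (0.00 log units; within the scatter). For compound 4 the estimate in this assay is 35000 nM, expected to lie between 12000 nM and 100000 nM.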

Compound 4, concentration for total growth inhibition: 41700 nM
Compound 4: middle estimate off by 1.2-fold (0.08 log units), on the low side, within the range that was stated.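

In this assay, among the compounds shown here, this is the first step that can be read: a 1.2-fold higher number from compound 2 to compound 4 (0.08 log units; within the scatter). The methoxy group in question sits on an aromatic carbon, ortho to a methoxy group and meta to a large group, and at this position the change from 3,4-dimethoxyphenyl to 4-methoxyphenyl leaves the two compounds indistinguishable in this test, so this methoxy group is not needed for the growth inhibition that compound 2 shows. That is a statement about one pair of compounds only, and no measurement shown here bears on why the two read alike.

The other steps in the series cannot be read, as compound 1 and compound 3 are known only through limits of the assay, so the effect of adding a further methoxy group to compound 2 remains unsettled. Also open, from the compounds shown here alone, is whether a different group at this same position, such as a hydroxyl, an amine or a carboxylic acid, would separate from hydrogen and methoxy, and whether the remaining methoxy group can be replaced by hydrogen or a longer chain.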